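Allylsulfanyl to (4-methylbenzyl)sulfanyl: working notes on compound 3

The source may report more compounds than this note shows. Statements on the series, on what has been measured and on what is new or still open speak of the compounds shown alone.

Measured so far in a functional assay on PC-9 cells (Homo sapiens) for inhibition, read by MTT assay, with a stated time of 72 h; a higher number here means a weaker inhibitor, a lower number a stronger inhibitor:
- compound 1 `Cc1cc(Nc2cc(-c3ccccc3)[nH]n2)n2nc(SCc3ccc(F)cc3)nc2n1`: 8110 nM
- compound 2 `C=CCSc1nc2nc(C)cc(Nc3cc(-c4ccccc4)[nH]n3)n2n1`: > 50000 nM (a limit)

Compound 2 has no number in this assay and stands only at the limit > 50000 nM.

The next compound to be measured is compound 3 `Cc1ccc(CSc2nc3nc(C)cc(Nc4cc(-c5ccccc5)[nH]n4)n3n2)cc1`. It differs from compound 2 as follows: 4-methylphenyl in place of vinyl on a saturated chain carbon bound to a sulfur. In words, 4-methylphenyl takes the place of vinyl on a saturated chain carbon bound to a sulfur.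

Among the measured compounds shown here, one measured step bears on this change: an at least 6.1-fold higher number from compound 1 to compound 2 (0.78 log units; beyond the scatter). There, vinyl replaced 4-fluorophenyl at the same place. The change to compound 3 runs the opposite way, from vinyl back to a phenyl group with a substituent in the 4-position, so a lower number is expected in this assay. Compound 1, at 8110 nM, is the best available guide to the level, although a single step is thin support.

The expected step is an at least 5.5-fold lower number from compound 2 to compound 3 (0.74 log units; beyond the scatter).

The value expected for compound 3 is 9000 nM, within an estimated range from 3000 nM to 30000 nM.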

Compound 3, half-maximal inhibitory concentration: 7310 nM
For compound 3 the middle estimate is 1.2-fold (0.09 log units) above the measured one; the measured number falls inside the stated range.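

In this assay, the gain on replacing vinyl with a substituted phenyl on the saturated chain carbon bound to a sulfur now appears in the direction opposite to the earlier loss (an at least 6.8-fold lower number from compound 2 to compound 3 (0.83 log units; beyond the scatter)), so the difference between the allylsulfanyl group and the benzyl-type groups is seen from both sides and does not rest on 4-fluorophenyl alone. Methyl in place of fluoro on an aromatic carbon gives no change that can be told apart (a 1.1-fold lower number from compound 1 to compound 3 (0.05 log units; within the scatter)), and so compound 1 and compound 3 read alike, with neither ahead of the other. Compound 2 still has no number and stands only at a limit, which leaves the size of its step to compound 3 open at one end: (the limit of > 50000 nM in this assay, at which 1 of the 3 values shown sits).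

The compounds shown leave open whether the unsubstituted phenyl, or a 4-methoxyphenyl, 4-carboxyphenyl or 4-aminophenyl group, would read differently from 4-fluorophenyl and 4-methylphenyl. They also leave open whether the aromatic ring itself matters or whether a saturated chain such as n-hexyl or a cyclohexyl ring on the sulfur-bound carbon would serve equally well.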